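Replacing Methyl with 2-Phenylethenyl on a Carbonyl Carbon

The compounds below may be only part of what the source reports. "The series", "measured", "known", "first", "only" and "open" are said of these compounds alone.

In a functional assay on U-937 cells (Homo sapiens) for cytotoxicity, read by resazurin assay, with a stated time of 72 h (on this read-out lower numbers stand for stronger inhibition and higher numbers for weaker inhibition), compound 3 (`COCOc1cc(OC)cc(OC)c1C(C)=O`) gives 13300 nM and stands within the scatter of compound 2 (`C=CCOc1ccccc1Cc1c(OC)cc(OC)c(C(=O)/C=C/c2ccccc2)c1OC`) at 7500 nM and of compound 1 (`COc1cc(OC)c(C(=O)/C=C/c2ccccc2)c(OC)c1`) at 6700 nM on the same read-out. Compound 4 (`COCOc1cc(OC)cc(OC)c1C(=O)/C=C/c1ccccc1`) differs from compound 3 by 2-phenylethenyl in place of methyl on a carbonyl carbon with 2-phenylethenyl in place of methyl on a carbonyl carbon. Among the compounds with values here, the only measured step is a 1.1-fold higher number from compound 1 to compound 2 (0.05 log units; within the scatter) for a different change, and it lies within the scatter. Compound 1 and compound 2 already carry 2-phenylethenyl on that carbonyl carbon, and their values lie within the scatter of compound 3, so no step beyond the scatter is expected in this assay for this change. The expected step is a 1.7-fold lower number from compound 3 to compound 4 (0.22 log units; within the scatter) and stays within the scatter. Compound 4 is estimated at 8000 nM with an expected range from 3500 nM to 16000 nM in this measurement.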

Compound 4, half-maximal inhibitory concentration: 2500 nM
Compound 4: middle estimate off by 3.2-fold (0.51 log units), on the high side; the whole stated range lies above it.
By their numbers in this assay, from the lowest: compound 4; then compounds 1, 2 and 3 (each within the scatter of the next).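

In this assay, 2-phenylethenyl in place of methyl on a carbonyl carbon gives a 5.3-fold lower number from compound 3 to compound 4 (0.73 log units; beyond the scatter) and is the first change shown here to step beyond the scatter. Methoxy in place of hydrogen on a saturated chain carbon bound to an oxygen on an aromatic ring also counts on the shared core, giving a 2.7-fold lower number from compound 1 to compound 4 (0.43 log units; beyond the scatter) on the same read-out. No evidence here accounts for either step.

From the compounds shown here alone, whether an amine or a longer chain in place of that methoxy would hold the lower number remains open. So does whether a carboxylic acid on the phenyl ring of the 2-phenylethenyl would.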